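Swapping an aminophenyl for dichlorophenyl on a chalcone-like pyrazole

The source may report more compounds than this note shows. Statements on the series, on what has been measured and on what is new or still open speak of the compounds shown alone.

Compound 1, with the structure `COc1cc(-c2cc(/C=C/C(=O)c3ccc(N)cc3)[nH]n2)cc(OC)c1OC`, was tested in a functional assay on K562 cells (Homo sapiens) for cytotoxicity, read by sulforhodamine B assay, with a stated time of 48 h, tested at 10 uM (on this read-out higher numbers stand for a weaker effect at the one concentration tested and lower numbers for a stronger effect), where compound 1 gives 2%. A second compound, compound 2 with the structure `COc1ccc(-c2cc(/C=C/C(=O)c3ccc(OC)c(OC)c3)[nH]n2)cc1`, gives 1% in this assay. Compound 1 carries the nominally higher of these two numbers, yet the gap to compound 2 lies within the scatter of repeated measurements, so the two cannot be told apart on this read-out.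

Compound 3, with the structure `COc1cc(-c2cc(/C=C/C(=O)c3ccc(Cl)c(Cl)c3)[nH]n2)cc(OC)c1OC`, has not yet been measured in this assay. Compared with compound 1 it differs in one place: 3,4-dichlorophenyl in place of 4-aminophenyl on a carbonyl carbon. Going by the values given here, no pair of measured compounds that differ in exactly one place is available, so there is no measured step to lean on for this change.

Both measured numbers sit near the bottom of the scale, and without a comparable step the expectation is that compound 3 stays in the same region. The expected step of a number 4 percentage points higher from compound 1 to compound 3 (within the scatter) is small, likely not beyond the scatter, though the uncertainty is wide. Compound 3 is therefore estimated at 6%, within a range from 0% to 45%.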

Compound 3, a percentage reported as activity, at one concentration (the size of the read-out at that concentration, not a potency): 28%
Estimate against measurement, compound 3: 22 percentage points below; the measured number falls inside the stated range.
By their numbers in this assay, from the lowest: compounds 2 and 1 (each within the scatter of the next); then compound 3.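

In this assay, putting 3,4-dichlorophenyl in place of 4-aminophenyl on a carbonyl carbon gives a number 26 percentage points higher from compound 1 to compound 3 (beyond the scatter) and so a weaker effect at the one concentration tested. Going by these compounds alone, this is the first comparison here in which only one group differs, and it shows that the group on this carbonyl carbon can move the read-out by more than ordinary scatter. The read-out comes from a single concentration. The step describes the size of the effect at that concentration and not a difference in potency. No measurement available here accounts for the shift.

Within the data shown here, the single swap replaces the amine with two chlorines, so it cannot show whether losing the amine, adding the chlorines or both lie behind the step. Going by these compounds, a plain phenyl ring, or a phenyl ring carrying a hydroxyl group or a single chlorine, would help separate these possibilities, and it also remains open whether the same swap would have a similar effect on a different core.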